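Oxygen-to-sulfur swap on the diaryl ether of compound 1

The source may report more compounds than this note shows. Statements on the series, on what has been measured and on what is new or still open speak of the compounds shown alone.

Compound 1 `Nc1cc(N)c2nc(-c3ccccc3)c(Oc3ccc(Cl)c(Cl)c3)nc2c1` carries a 3,4-dichlorophenoxy group on the shared core. In a functional assay on ACHN cells (Homo sapiens) for inhibition, read by sulforhodamine B assay, with a stated time of 48 h (on this read-out higher numbers stand for weaker inhibition of growth and lower numbers for stronger inhibition of growth), compound 1 gives 9330 nM. Within the data shown here, of the values shown, only one other is a number: compound 3 `COc1cc(CNc2nc3cc(N)cc(N)c3nc2-c2ccccc2)cc(OC)c1OC` gives 5370 nM in this assay, and the gap between compound 1 and compound 3 lies within the scatter, so the two cannot be ordered. Among the measured compounds shown here, compound 2 `CCOC(=O)[C@H](CCC(=O)O)NC(=O)c1ccc(CNc2nc3cc(N)cc(N)c3nc2-c2ccccc2)cc1` reaches only a limit of the assay, < 100000 nM in this assay, and this is the one value of the three that sits at the limit of < 100000 nM in this assay, at which 1 of the 3 values shown sits.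

Compound 4 `Nc1cc(N)c2nc(-c3ccccc3)c(Sc3ccc(Cl)c(Cl)c3)nc2c1` differs from compound 1 in one place: (3,4-dichlorophenyl)sulfanyl in place of 3,4-dichlorophenoxy on an aromatic carbon. For the measured compounds named here, no pair of measured compounds shows this change, so its size is not known from the series. The group that leaves and the group that enters have the same count of heavy atoms, the same ring and the same counts of donors and acceptors, and a step within the scatter, in either direction, is the plain expectation. For compound 4 the estimate in this assay is 8000 nM, with a range from 2500 nM to 25000 nM. The step expected from compound 1 to compound 4 is a 1.2-fold lower number from compound 1 to compound 4 (0.07 log units; within the scatter), not beyond the scatter.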

Compound 4, concentration for 50% growth inhibition: 1700 nM
Estimate against measurement, compound 4: 4.7-fold (0.67 log units) above; the measured number lies below the stated range.
By their numbers in this assay, from the lowest: compound 4; then compounds 3 and 1 (each within the scatter of the next).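

The atom that joins the 3,4-dichlorophenyl group to the shared core, on the aromatic carbon next to the ring nitrogen, matters in this series: in this assay, sulfur in place of oxygen gives a 5.5-fold lower number from compound 1 to compound 4 (0.74 log units; beyond the scatter). This step appears although the leaving and entering groups have the same heavy-atom count, the same ring and the same counts of donors and acceptors, so the series is sensitive here to a swap of one atom. The earlier compounds offered no pair differing in one place, and no measured property shown here accounts for the size of this step.

As far as these compounds go, whether other links at this carbon, such as a methylene, a sulfoxide or a sulfone, would match or exceed the sulfur remains open. Also open, from the compounds shown here alone, is whether the same swap gives a comparable step when the 3,4-dichloro pattern is replaced, for example by a single methoxy group or a single fluorine on the phenyl ring.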